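The source may report more compounds than this note shows. Statements on the series, on what has been measured and on what is new or still open speak of the compounds shown alone.

Compound 1 `CNC(=O)c1cc(Oc2cccc(NC(=S)Nc3ccc(Cl)cc3)c2)ccn1` gives > 100000 nM in a functional assay on MDA-MB-231 cells (Homo sapiens) for cytotoxicity, read by MTT assay, with a stated time of 48 h (on this read-out higher numbers stand for weaker inhibition and lower numbers for stronger inhibition), which is a limit of the assay.
Compound 2 `CC(C)NC(=O)c1cc(Oc2cccc(NC(=S)Nc3ccc(Cl)cc3)c2)ccn1` gives 87500 nM in this assay.
Compound 3 `CNC(=O)c1cc(Oc2cccc(NC(=S)Nc3ccc(F)c(F)c3)c2)ccn1` gives > 100000 nM in this assay, which is a limit of the assay.

Compound 3 thus stands only at a limit, and compound 1 sits at the same limit (the limit of > 100000 nM in this assay, at which 2 of the 3 values shown sit). Compound 4 `O=C(NC1CCCCC1)c1cc(Oc2cccc(NC(=S)Nc3ccc(F)c(F)c3)c2)ccn1` differs from compound 3 by cyclohexyl in place of methyl on an amide-type nitrogen. Among the compounds with values here, the one measured step that also replaces the methyl on the amide-type nitrogen is an at least 1.1-fold lower number from compound 1 to compound 2 (0.05 log units; that floor lies within the scatter), which stays within the scatter; the step that the two limits leave unreadable from compound 1 to compound 3 is not readable. On that basis the change in compound 4 is expected to bring no more than a modest move, an at least 1.4-fold lower number from compound 3 to compound 4 (0.15 log units; that floor lies within the scatter), in this assay. Compound 4 is therefore estimated at 70000 nM, in a range from 25000 nM to 200000 nM.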

Compound 4, half-maximal inhibitory concentration: > 100000 nM
Compound 4 was reported as a limit; the forecaster's own chance of this, stated with the estimate: 45%; at least 1.4-fold (0.15 log units) between middle value and limit.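

No step can be read from compound 3 to compound 4, since both are reported only as a limit: the limit of > 100000 nM in this assay, at which 3 of the 4 values shown sit.

The compounds shown leave open whether in this assay cyclohexyl in place of methyl on an amide-type nitrogen moves the number at all.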